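A Methyl on the Chain Carbon of Compound 3

A few compounds are considered here, and "the series" means these few. Any claim that something is new, unique, unknown or untested is made for them only; others in the source may bear on it.

Three measured compounds share one core and differ only in the arm that carries the carboxylic acid. Compound 1 `CN(Cc1cccc(C(=O)O)c1)c1ccc(OCc2c(-c3c(Cl)cccc3Cl)noc2C2CC2)nc1C(F)(F)F` gives 9 nM in a functional assay on HEK293 cells for agonist activity at Bile acid receptor (Homo sapiens); on this read-out lower numbers stand for an effect already at smaller amounts and higher numbers for an effect only at larger amounts of compound. Compound 2 `O=C(O)c1ccccc1OCc1ccc(OCc2c(-c3c(Cl)cccc3Cl)noc2C2CC2)nc1C(F)(F)F` gives 1710 nM, and compound 3 `O=C(O)c1ccc(OCc2ccc(OCc3c(-c4c(Cl)cccc4Cl)noc3C3CC3)nc2C(F)(F)F)cc1` gives 95 nM. Among these three numbers compound 3 stands second highest: an 11-fold higher number from compound 1 to compound 3 (1.02 log units; beyond the scatter), while an 18-fold lower number from compound 2 to compound 3 (1.26 log units; beyond the scatter). The widest gap is a 190-fold higher number from compound 1 to compound 2 (2.28 log units; beyond the scatter).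

Compound 4 `CC(Oc1ccc(C(=O)O)cc1)c1ccc(OCc2c(-c3c(Cl)cccc3Cl)noc2C2CC2)nc1C(F)(F)F` keeps everything of compound 3 and differs in a single place: methyl in place of hydrogen on a saturated chain carbon bound to an aromatic carbon and an oxygen on an aromatic ring. For the measured compounds named here, none of the measured steps touches this saturated chain carbon; all three reshape the carboxyphenyl arm itself, and each of them was large. Going by the values given here, no measured step therefore bears directly on the change from compound 3 to compound 4, and a single methyl entering at this place, with no ring, no donor and no acceptor, offers no ground to expect a step beyond the scatter in either direction in this assay. Compound 4 is expected to give about 95 nM in this assay, most likely between 30 nM and 300 nM. This estimate means no change at the digits printed from compound 3 to compound 4 (within the scatter), an expected step that stays inside the usual scatter.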

Compound 4, half-maximal effective concentration: 189 nM
The estimate for compound 4 lay 2.0-fold (0.30 log units) below the measured number, and the stated range covers the measured number.
By their numbers in this assay, from the lowest: compound 1; then compounds 3 and 4 (each within the scatter of the next); then compound 2.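

For the compounds shown here, on this saturated chain carbon, methyl in place of hydrogen gives a step within the usual scatter in this assay (a 2.0-fold higher number from compound 3 to compound 4 (0.30 log units; within the scatter)), so compound 3 and compound 4 cannot be told apart, and this carbon is the first place where a change shows no step beyond the scatter. Going by these compounds alone, the wider picture also holds with the 1-(4-carboxyphenoxy)ethyl arm, since the gaps to the other two compounds remain beyond the scatter (a 9.0-fold lower number from compound 2 to compound 4 (0.96 log units; beyond the scatter)) and (a 21-fold higher number from compound 1 to compound 4 (1.32 log units; beyond the scatter)), with the gap to compound 1 still large and the one to compound 2 modest. Nothing measured here gives a reason why the methyl is accommodated at this carbon.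

The compounds shown leave open whether a larger or different group on this carbon, such as an ethyl, a hydroxyl or an amine, would also stay within the scatter of compound 3. They also leave open whether a methyl at the same carbon would give so small a step on the (2-carboxyphenoxy)methyl arm of compound 2.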